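The compounds below may be only part of what the source reports. "The series", "measured", "known", "first", "only" and "open" are said of these compounds alone.

Measured so far:
compound 1 `N#C/C(=C\c1ccc(O)c(O)c1)C(=O)N1CCOCC1`: 40%
compound 2 `CC(C)(C)OC(=O)/C(C#N)=C/c1ccc(O)c(O)c1`: 43.4%

In a functional assay on the whole organism (strain CD1) for inhibition, with Mus musculus as the target, with stated times of 15 min and 20 min, at a dose of 10 mg/kg by the subcutaneous route (on this read-out lower numbers stand for less inhibition and higher numbers for more inhibition at the one dose given (going by the name of the read-out)), compound 1 gives 40%, and the two measured numbers lie within the usual scatter of each other, so compound 1 is not set apart from compound 2 on this read-out. Compound 3 `N#C/C(=C\c1ccc(O)c(O)c1)C(=O)OC1CCCCC1` is the next entry in the series. Compared with compound 1, the change is cyclohexyloxy in place of morpholin-4-yl on a carbonyl carbon. Within the data shown here, the one step that bears on it, an exchange of the same group for an alkoxy substituent on the carbonyl carbon, was a number 3.4 percentage points higher from compound 1 to compound 2 (within the scatter). No step beyond the scatter is therefore expected here, with an estimated a number 3 percentage points higher from compound 1 to compound 3 (within the scatter). For compound 3 the expected value in this assay is 43%, with a range from 30% to 56%.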

Compound 3, a percentage reported as inhibition, in the whole organism at one dose (the size of the read-out at that dose, not a potency): 55.3%
Beside the measured number, compound 3's estimate is 12.3 percentage points below it; the range from low to high includes it.
By their numbers in this assay, from the lowest: compounds 1 and 2 (each within the scatter of the next); then compound 3.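

In this assay the group on a carbonyl carbon can shift the read-out, as cyclohexyloxy in place of morpholin-4-yl gives a number 15.3 percentage points higher from compound 1 to compound 3 (beyond the scatter) whereas tert-butoxy did not separate from morpholin-4-yl. The group on the oxygen next to a carbonyl group also counts, with cyclohexyl in place of tert-butyl giving a number 11.9 percentage points higher from compound 2 to compound 3 (beyond the scatter) and thus more than the ester link alone. Nothing at hand explains either step. Open, from the compounds shown here alone, is whether the cyclohexyl ring itself is needed, or whether a straight hexyl chain on the same oxygen would serve equally. A piperidin-1-yl amide would show whether a carbon-only ring also holds on nitrogen.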